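The source may report more compounds than this note shows. Statements on the series, on what has been measured and on what is new or still open speak of the compounds shown alone.

Measured compounds:
compound 1, `Clc1cncc(OC[C@@H]2CCN2)c1`, 0.042 nM in an assay on brain for binding affinity to Neuronal acetylcholine receptor; alpha4/beta2 (Rattus norvegicus), read by radioligand binding; on this read-out lower numbers stand for stronger inhibition and higher numbers for weaker inhibition
compound 2, `Clc1cc(OC[C@@H]2CCN2)cnc1Cl`, 0.023 nM

Compound 1 gives the higher of the two numbers in this assay, and its nearest neighbour is compound 2, separated by a 1.8-fold lower number from compound 1 to compound 2 (0.26 log units; within the scatter), a change that consists of chloro in place of hydrogen on an aromatic carbon.

Compound 3, `Clc1cncc(OC[C@H]2CCN2)c1`, has not yet been measured. Its difference from compound 1 is the two compounds have the same atoms and bonds and differ only in configuration as drawn: 1 of 1 stereo elements differ; a stereocentre at a saturated ring carbon is drawn S in compound 1 and R in compound 3. Going by the values given here, no measured step touches a change of configuration; the only step available, from compound 1 to compound 2, alters an aromatic substituent and says nothing about the drawn stereocentre. The size and direction of the step from compound 1 to compound 3 are therefore open, and the estimate must be broad.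

Compound 3 is expected to give 0.5 nM in this assay, with a range from 0.04 nM to 6 nM, which would mean an estimated step of a 12-fold higher number from compound 1 to compound 3 (1.08 log units; beyond the scatter).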

Compound 3, inhibition constant: 0.12 nM
Estimate against measurement, compound 3: 4.2-fold (0.62 log units) above, and the stated range covers the measured number.
By their numbers in this assay, from the lowest: compounds 2 and 1 (each within the scatter of the next); then compound 3.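

Turning the stereocentre at a saturated ring carbon from S to R gives a 2.9-fold higher number from compound 1 to compound 3 (0.46 log units; beyond the scatter) in this assay, the first step among these compounds to lie beyond the scatter. The gap can be assigned to that stereocentre alone because of one plain structural fact: the fact that compounds 1 and 3 differ only in the configuration as drawn. So the drawn configuration at this position does count in this assay, although the step is modest, and compound 3 still gives 0.12 nM.

From the compounds shown here alone, whether the same change of configuration would give a step of similar size on compound 2, which carries the second chloro, remains open. Also open, going by these compounds, is how either configuration would fare with an amine or a carboxylic acid in place of the chloro on the shared core.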